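Para-halogen swap on the anilino ring of compound 1

The source may hold more compounds than are shown below. What is called first, only, known or untested is meant among the compounds shown, and "the series" means these compounds.

Compound 1 `O=C(CNc1ccc(F)cc1)Nc1nc2ccc(Cl)cc2s1` and compound 2 `Oc1ccc(/C=N/NC(=S)Nc2nc3ccc(Cl)cc3s2)cc1` share one core. Among the compounds with values here, in a functional assay on the whole organism with Mus musculus as the target, in the maximal electroshock model, with a stated time of 0.5 h (a higher number here means that more compound is needed for the effect, a lower number that less compound is needed), compound 1 gives 100 mg/kg and compound 2 gives 100 mg/kg; the two values coincide, within the scatter, so compound 1 stands level with its only measured neighbour. Compound 3 `O=C(CNc1ccc(Cl)cc1)Nc1nc2ccc(Cl)cc2s1` differs from compound 1 by chloro in place of fluoro on an aromatic carbon. Within the data shown here, no measured pair covers a change of this kind, and the two values show nothing that points either way; the step of no change at the digits printed from compound 1 to compound 3 (within the scatter) is therefore expected to be none beyond the scatter. For compound 3 in this assay the estimate is 100 mg/kg, within 50 mg/kg to 200 mg/kg.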

Compound 3, minimum effective dose in the Mus musculus assay: 100 mg/kg
For compound 3 middle estimate and measured number coincide at the digits printed; the range from low to high includes it.
By their numbers in the Mus musculus assay, from the lowest: compounds 1, 2 and 3 (each within the scatter of the next).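

Within the data shown here, in the Mus musculus assay, chloro in place of fluoro on an aromatic carbon gives no change at the digits printed from compound 1 to compound 3 (within the scatter), the first step read at a single place. In a physicochemical assay for lipophilicity, in phosphate buffer, measured as octanol-water partition (a lower number here means a more polar compound, a higher number a more lipophilic compound), compound 1 gives 3.88 and compound 3 gives 4.24. This halogen swap therefore makes the compound measurably more lipophilic without a matching shift in minimum effective dose: the measured partition coefficient of compound 1, 3.88, and of compound 3, 4.24, a number 0.36 log units higher (beyond the scatter)

Going by these compounds, what an amine or a carboxylic acid at this place would do in the Mus musculus assay stays open. So does whether any change on this ring can move the dose at all.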